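This account rests on a few compounds, and the source may have more. Where it says the series, first, only, none or still open, it means among the compounds named here.

Going by the values given here, compound 2 `Cc1ccc(NC(=O)NC(=O)c2ccc(OCc3cccc(F)c3)cc2)cc1-c1nc2ccccc2[nH]1` gives the higher of the two numbers so far: in a functional assay on MGC-803 cells (Homo sapiens) for inhibition, read by MTT assay, with a stated time of 48 h (on this read-out higher numbers stand for weaker inhibition and lower numbers for stronger inhibition), compound 2 gives 44800 nM, whereas compound 1 `Cc1ccc(NC(=O)NC(=O)c2ccc(OCc3ccccc3F)cc2)cc1-c1nc2ccccc2[nH]1` gives 2520 nM. Among the compounds with values here, the step of an 18-fold higher number from compound 1 to compound 2 (1.25 log units; beyond the scatter) is the only measured change and it concerns the same position that now moves again. Compound 3 `Cc1ccc(NC(=O)NC(=O)c2ccc(OCc3ccccc3Cl)cc2)cc1-c1nc2ccccc2[nH]1` differs from compound 2 by 2-chlorophenyl in place of 3-fluorophenyl on a saturated chain carbon bound to an oxygen on an aromatic ring. Since the halogen returns to the position it held in compound 1, the step from compound 2 to compound 3 is expected to run the other way, towards a lower number, roughly an 11-fold lower number from compound 2 to compound 3 (1.05 log units; beyond the scatter). Compound 3 is therefore estimated at 4000 nM, with a range from 1200 nM to 15000 nM.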

Compound 3, half-maximal inhibitory concentration: 19500 nM
Beside the measured number, compound 3's estimate is 4.9-fold (0.69 log units) below it, outside the stated range (above it).
By their numbers in this assay, from the lowest: compound 1; then compound 3; then compound 2.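

In this assay, moving to 2-chlorophenyl in place of 3-fluorophenyl recovers only part of the earlier loss, with a 2.3-fold lower number from compound 2 to compound 3 (0.36 log units; beyond the scatter). The halogen itself therefore matters here and not only where it sits: chloro in place of fluoro on the same aromatic carbon gives a 7.7-fold higher number from compound 1 to compound 3 (0.89 log units; beyond the scatter). No measurement is at hand that accounts for either step. The compounds shown leave open how 3-chlorophenyl would compare with 3-fluorophenyl. They also leave open whether a methoxy group or an amine in the halogen's place would come closer to compound 1 than chloro does.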